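Oxan-4-yl in Place of Methyl on an Aromatic Nitrogen

The compounds below may be only part of what the source reports. "The series", "measured", "known", "first", "only" and "open" are said of these compounds alone.

Compound 3 `CN(C)C(=O)CN1CCC(c2cc3c(-c4ccc(=O)n(C)c4)ccnc3[nH]2)CC1` was run in an ADME assay on microsomes from liver (Homo sapiens) for metabolic stability; a higher number here means faster removal of the compound, a lower number slower removal. In this assay compound 3 gives < 3 uL/min, which is a limit of the assay and not a number. Compound 1 `CN(C)C(=O)CN1CCC(c2cc3c(-c4ccc(=O)n(C5CCC5)c4)ccnc3[nH]2)CC1` carries cyclobutyl on the same aromatic nitrogen. In this assay compound 1 likewise gives < 3 uL/min, again a limit. The step that the two limits leave unreadable from compound 1 to compound 3 therefore cannot be read, as the limit of < 3 uL/min in this assay, at which 2 of the 3 values shown sit, shows. Compound 2 `CC(C)n1nc(-c2ccnc3[nH]c(C4CCN(CC(=O)N(C)C)CC4)cc23)ccc1=O` differs from compound 3 in another part of the molecule, and in this assay compound 2 gives 13 uL/min. The resulting step is an at least 4.3-fold lower number from compound 2 to compound 3 (0.63 log units; beyond the scatter). Compound 4 `CN(C)C(=O)CN1CCC(c2cc3c(-c4ccc(=O)n(C5CCOCC5)c4)ccnc3[nH]2)CC1` has not yet been measured. It differs from compound 3 by oxan-4-yl in place of methyl on an aromatic nitrogen. Within the data shown here, the only measured comparison that touches this position, between compound 1 and compound 3, sits at the limit on both sides, so no step beyond the scatter is expected from it. Compound 4 is expected to give 3 uL/min in this assay, with a range from 1.5 uL/min to 8 uL/min. That estimate means an expected step of a number no lower from compound 3 to compound 4 (the limit leaves the size open), within the scatter.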

Compound 4, intrinsic clearance in a liver preparation (reported as CLH), per the amount of preparation that the assay uses: 8.2 uL/min
Compound 4: the middle estimate sits 2.7-fold (0.44 log units) below what was measured, outside the stated range (above it).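

In this assay the group on this aromatic nitrogen now makes a readable difference, which the earlier pair could not show, as the step between compound 1 and compound 3 cannot be read: the limit of < 3 uL/min in this assay, at which 2 of the 4 values shown sit. Oxan-4-yl in place of methyl brings an at least 2.7-fold higher number from compound 3 to compound 4 (0.43 log units; beyond the scatter), and oxan-4-yl in place of cyclobutyl brings an at least 2.7-fold higher number from compound 1 to compound 4 (0.43 log units; beyond the scatter). As far as these compounds go, the values of compound 1 and compound 3 are limits of the assay and not numbers, so the full size of both steps stays open.

The compounds shown do not tell whether the ring oxygen of oxan-4-yl or the six-membered ring itself goes with the higher number, since cyclohexyl on this nitrogen is not among them. From the compounds shown here alone, how an open-chain ether such as 2-methoxyethyl or a ring amine such as piperidin-4-yl would read at this position also stays open.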